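The source may report more compounds than this note shows. Statements on the series, on what has been measured and on what is new or still open speak of the compounds shown alone.

Measured in an ADME assay on PBMC cells (Homo sapiens) for activation; a lower number here means a stronger inhibitor, a higher number a weaker inhibitor:
- Compound 1 `Cn1cc(-c2cccc(O)c2)c2c(N[C@H](CO)c3ccccc3)ncnc21`: > 10000 nM
- Compound 2 `COc1cc(CO)ccc1-c1cc2c(N[C@H](CO)c3ccc(F)cc3)ncnc2[nH]1`: > 10000 nM
- Compound 3 `C[C@@H](Nc1ncnc2[nH]cc(-c3ccc(F)c(CO)c3)c12)c1ccccc1`: > 10000 nM

All three entries are limits of the assay and not numbers, so no ranking can be drawn among these compounds. Among the measured compounds shown here, the whole series so far comes down to one line: the limit of > 10000 nM in this assay, at which 3 of the 3 values shown sit.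

Compound 3 stands with the other two compounds, and its entry gives no exact potency. Its reading of > 10000 nM is a limit.

The next compound, compound 4 `C[C@@H](Nc1ncnc2[nH]cc(-c3ccc(F)c(CNCCN(C)C)c3)c12)c1ccccc1`, differs from compound 3 in one place: (2-(dimethylamino)ethyl)amino in place of hydroxy on a saturated chain carbon bound to an aromatic carbon. In words, (2-(dimethylamino)ethyl)amino comes in place of hydroxy on a saturated chain carbon bound to an aromatic carbon, so that hydroxymethyl becomes ((2-(dimethylamino)ethyl)amino)methyl.

For the measured compounds named here, no pair of measured compounds differing in one place is available, so the size of such a change in this assay cannot be read from the data. No shift beyond the usual scatter is expected, and the assay may well report only a limit again. As a step, the expected change is a number no higher from compound 3 to compound 4 (the limit leaves the size open). For compound 4 the estimate is 10000 nM, with an expected range from 3000 nM to 30000 nM.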

Compound 4, half-maximal inhibitory concentration: > 10000 nM
Compound 4: only a limit was reported; the forecaster's own chance of this, stated with the estimate: 65%; the middle value sits exactly at the limit.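

In this assay compound 4 gives > 10000 nM, which is a limit of the assay and not a number. Compound 3 also carries only a limit, so no step can be read between compound 3 and compound 4. The compounds shown leave open how any single change affects the read-out, as all of them rest on one line: the limit of > 10000 nM in this assay, at which 4 of the 4 values shown sit.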